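Extension of the piperidine side chain in a benzamide series

This account rests on a few compounds, and the source may have more. Where it says the series, first, only, none or still open, it means among the compounds named here.

Two benzamides have been measured so far. Compound 1 `COc1cc(N)c(Cl)cc1C(=O)NCCN1CCNCC1` gives 1260 nM in an assay on HEK293 cells for displacement of a labelled ligand from 5-hydroxytryptamine receptor 4 (Homo sapiens), read by scintillation counting; a lower number here means a stronger inhibitor, a higher number a weaker inhibitor. Compound 2 `CCN1CCC(NC(=O)c2cc(Cl)c(N)cc2OC)CC1` gives 1000 nM in this assay; this is the lower of the two numbers, but the gap to compound 1 lies within the scatter, so the two compounds cannot be ordered on these data.

Compound 3 `COc1cc(N)c(Cl)cc1C(=O)NC1CCN(CCN2CCN(S(C)(=O)=O)CC2)CC1` has not yet been measured. It differs from compound 2 by 4-(methylsulfonyl)piperazin-1-yl in place of hydrogen on a saturated chain carbon, two bonds along the chain from an amine nitrogen in a ring. For the measured compounds named here, no measured pair shows this kind of change, so nothing in the data fixes its size or direction. The two measured compounds differ only in their amine portion and give similar numbers, which says nothing about a change of this extent. A moderate reduction of the number is expected, beyond the scatter but uncertain: the step from compound 2 to compound 3 is estimated at a 3.3-fold lower number from compound 2 to compound 3 (0.52 log units; beyond the scatter). Compound 3 is therefore expected to give about 300 nM in this assay, between 60 nM and 1500 nM.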

Compound 3, inhibition constant: 126 nM
Compound 3: the middle estimate sits 2.4-fold (0.38 log units) above what was measured; measured number inside the range.
By their numbers in this assay, from the lowest: compound 3; then compounds 2 and 1 (each within the scatter of the next).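

In this assay, the saturated chain carbon two bonds along the chain from an amine nitrogen in a ring accepts a substituent of 10 heavy atoms without loss: 4-(methylsulfonyl)piperazin-1-yl in place of hydrogen gives a 7.9-fold lower number from compound 2 to compound 3 (0.90 log units; beyond the scatter). For the compounds shown here, this is the first step that lies beyond the scatter, and the first to show that this position affects the number at all; compounds 1 and 2 could not show this. No measurement on these compounds accounts for the size of the step.

One substituent cannot separate the contribution of the piperazine ring from that of the methylsulfonyl group. Open, on these data alone, is whether the step survives with plain piperazin-1-yl, with morpholin-4-yl, or with a longer chain carrying the same group.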